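The source may hold more compounds than are shown below. What is called first, only, known or untested is meant among the compounds shown, and "the series" means these compounds.

Two compounds here share one core and differ only in the side chain on one aromatic carbon. Compound 1 `Cc1nc(C(C)C)n2c(O)nnc(-c3ccccc3)c12` carries an isopropyl group there, and compound 2 `CCCc1nc(C)c2c(-c3ccccc3)nnc(O)n12` carries a propyl group in its place. Both were tested in a functional assay for inhibition, with Homo sapiens as the target; a lower number here means a stronger inhibitor, a higher number a weaker inhibitor. Compound 1 reaches only the limit of > 48000 nM in this assay, so no number is known for it. Compound 2 likewise reaches only the limit of > 48000 nM in this assay. Going by these compounds, the step that the two limits leave unreadable from compound 1 to compound 2 cannot be read, because the limit of > 48000 nM in this assay, at which 2 of the 2 values shown sit, holds both values, and so its size and direction stay unknown.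

The next compound, compound 3 `CCc1nc(C)c2c(-c3ccccc3)nnc(O)n12`, differs from compound 2 by hydrogen in place of methyl on a saturated chain carbon, two bonds along the chain from an aromatic carbon. Among the compounds with values here, no measured step gives the size of such a change, since the only step known is hidden behind the limits. With compound 2 at the limit and the side chain shortened by one carbon, compound 3 is expected to remain at the limit, estimated at 60000 nM, with a range from 20000 nM to 200000 nM. The step that the limit leaves unreadable from compound 2 to compound 3 is expected to lie within the usual scatter.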

Compound 3, half-maximal inhibitory concentration: > 48000 nM
Compound 3 gave a limit, no number; the forecaster's own chance of this, stated with the estimate: 85%; the middle value is on the limit's open side.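

Compound 3, like compound 2 and compound 1, gives only a limit in this assay, not a number. The steps among these compounds therefore cannot be read in size or direction, because all their values sit at one limit: the limit of > 48000 nM in this assay, at which 3 of the 3 values shown sit.

The compounds shown leave open how propyl, isopropyl and ethyl side chains on the shared core truly rank.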